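From a dichlorophenyl sulfide to a fluorophenyl sulfide

This account rests on a few compounds, and the source may have more. Where it says the series, first, only, none or still open, it means among the compounds named here.

Compound 3 `Nc1cc(N)c2nc(-c3ccccc3)c(Sc3ccc(Cl)c(Cl)c3)nc2c1` was tested in a functional assay on NCI/ADR-RES cells (Homo sapiens) for inhibition, read by sulforhodamine B assay, with a stated time of 48 h (a lower number here means a stronger inhibitor of growth, a higher number a weaker inhibitor of growth), where compound 3 gives 60300 nM. For the measured compounds named here, of the two numbers known, this is the highest; the nearest is compound 1 `Nc1cc(N)c2nc(-c3ccccc3)c(NCc3ccc(F)cc3)nc2c1`, which in this assay gives 5750 nM, and the step of a 10-fold higher number from compound 1 to compound 3 (1.02 log units; beyond the scatter) is large. Compound 2 `COc1ccc(Sc2nc3cc(N)cc(N)c3nc2-c2ccccc2)cc1` in this assay gives < 100000 nM, which is a limit of the assay and not a number (the limit of < 100000 nM in this assay, at which 1 of the 3 values shown sits). The steps a step that the limit leaves unreadable from compound 1 to compound 2 and a step that the limit leaves unreadable from compound 2 to compound 3 are therefore unreadable. Compound 4 `Nc1cc(N)c2nc(-c3ccccc3)c(Sc3ccc(F)cc3)nc2c1` has not yet been measured. It differs from compound 3 by 4-fluorophenyl in place of 3,4-dichlorophenyl on a sulfur. Going by the values given here, no measured step covers this change directly; the only measured step that swaps one aryl group on the sulfur for another is a step that the limit leaves unreadable from compound 2 to compound 3, and its size is hidden by the limit. Compound 3 thus serves as the anchor, and the step is expected to be small, a 1.2-fold lower number from compound 3 to compound 4 (0.08 log units; within the scatter). Compound 4 is accordingly estimated at 50000 nM, with a range from 15000 nM to 150000 nM.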

Compound 4, concentration for total growth inhibition: 34700 nM
The estimate for compound 4 lay 1.4-fold (0.16 log units) above the measured number; low and high end bracket the measured number.
By their numbers in this assay, from the lowest: compound 1; then compounds 4 and 3 (each within the scatter of the next).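

In this assay, for the compounds shown here, a swap of the aryl group on the sulfur can now be read for the first time, and it stays within the scatter (a 1.7-fold lower number from compound 3 to compound 4 (0.24 log units; within the scatter)), so these two sulfides cannot be told apart. The change at this position that does register is the one from the amino link to the sulfur link: it remains beyond the scatter with the 4-fluorophenyl group as well (a 6.0-fold higher number from compound 1 to compound 4 (0.78 log units; beyond the scatter)), as it did with the 3,4-dichlorophenyl group. Compound 2 carries a limit and not a number, so its steps cannot be read: the limit of < 100000 nM in this assay, at which 1 of the 4 values shown sits.

The compounds shown do not separate the sulfur from the extra carbon of the benzyl group, which a (4-fluorobenzyl)sulfanyl group would do. As far as these compounds go, how an amine or a carboxylic acid on the aryl ring would fare also stays open.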